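The compounds below may be only part of what the source reports. "The series", "measured", "known", "first", "only" and "open" are said of these compounds alone.

The three compounds measured here share one core and differ in the aromatic group carried on a nitrogen on an aromatic ring, and in one case also in the urea end. Compound 1 `CCc1ccc(Nc2cc(NC(=O)Nc3cc(OC)cc(OC)c3)ncn2)cc1` is the point of departure: in a functional assay on NCI-H226 cells (Homo sapiens) for inhibition, read by MTT assay, with a stated time of 48 h, tested at 10 uM (on this read-out lower numbers stand for less inhibition and higher numbers for more inhibition at the one concentration tested (going by the name of the read-out)), compound 1 gives 50.1%, the highest of the three numbers. Compound 3 `COc1cc(NC(=O)Nc2cc(Nc3ccc(F)c(Cl)c3)ncn2)cc(OC)c1`, which carries 3-chloro-4-fluorophenyl in place of 4-ethylphenyl, gives 36.7%, so that a number 13.4 percentage points lower from compound 1 to compound 3 (beyond the scatter). Compound 2 `COc1ccc(F)cc1Nc1cc(NC(=O)Nc2c(Cl)cccc2Cl)ncn1` differs from compound 1 in two places at once; in this assay compound 2 gives 31.3%.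

Compound 4 `COc1cc(NC(=O)Nc2cc(Nc3cc(F)ccc3OC)ncn2)cc(OC)c1` has not yet been measured. It differs from compound 1 in one place: 5-fluoro-2-methoxyphenyl in place of 4-ethylphenyl on a nitrogen on an aromatic ring. Among the compounds with values here, the only measured step of the same kind, a change of the aromatic group on that nitrogen, is the one from compound 1 to compound 3, which was a modest fall beyond the scatter. Compound 2 carries the same 5-fluoro-2-methoxyphenyl group as compound 4 but also a different urea end, so its value can only hint at the direction. A fall of similar size is therefore expected, a number 13.1 percentage points lower from compound 1 to compound 4 (beyond the scatter), and compound 4 is estimated at 37%, between 22% and 52%.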

Compound 4, a percentage reported as inhibition, at one concentration (the size of the read-out at that concentration, not a potency): 37.7%
The estimate for compound 4 lay 0.7 percentage points below the measured number, and the stated range covers the measured number.
By their numbers in this assay, from the lowest: compounds 2, 3 and 4 (each within the scatter of the next); then compound 1.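

In this assay a second replacement of 4-ethylphenyl on a nitrogen on an aromatic ring also gives less inhibition (a number 12.4 percentage points lower from compound 1 to compound 4 (beyond the scatter)), so the fall is not peculiar to 3-chloro-4-fluorophenyl. The two replacing groups cannot be told apart (a number 1 percentage points higher from compound 3 to compound 4 (within the scatter)), and at the urea end, with 5-fluoro-2-methoxyphenyl held fixed, the two aryl groups cannot be told apart either (a number 6.4 percentage points higher from compound 2 to compound 4 (within the scatter)). Nothing available explains why compound 1 gives the highest number.

On these data alone, it remains open whether the ethyl group itself matters, since a plain phenyl, 4-methylphenyl or a longer chain such as 4-butylphenyl would be needed to show that. As far as these compounds go, an amine such as 4-(dimethylamino)phenyl at the same place is also open, and a single concentration in one cell line says nothing about potency.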